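Chloro in place of nitro on the aromatic ring

The source may report more compounds than this note shows. Statements on the series, on what has been measured and on what is new or still open speak of the compounds shown alone.

In a functional assay on UACC-62 cells (Homo sapiens) for cytotoxicity, read by sulforhodamine B assay (on this read-out lower numbers stand for stronger inhibition of growth and higher numbers for weaker inhibition of growth), compound 1 `CC1=CC[C@@H]([C@@](C)(O)CCCC(C)(C)NC(=S)N/N=C\c2ccccc2)CC1` gives 12700 nM and compound 3 `CC1=CC[C@@H]([C@@](C)(O)CCCC(C)(C)NC(=S)N/N=C\c2ccc([N+](=O)[O-])cc2)CC1` gives 20800 nM, so compound 3 stands level with compound 1 within the scatter. Compound 2 `CC1=CC[C@@H]([C@@](C)(O)CCCC(C)(C)NC(=S)N/N=C\c2ccc(N(C)C)cc2)CC1` gives > 100000 nM, which is a limit and not a number. Compound 4 `CC1=CC[C@@H]([C@@](C)(O)CCCC(C)(C)NC(=S)N/N=C\c2ccc(Cl)cc2)CC1` carries chloro in place of nitro on an aromatic carbon. For the measured compounds named here, three measured steps bear on this change. Nitro in place of hydrogen gave a 1.6-fold higher number from compound 1 to compound 3 (0.21 log units; within the scatter), while dimethylamino gave an at least 7.8-fold higher number from compound 1 to compound 2 (0.89 log units; beyond the scatter), and nitro in place of dimethylamino gave an at least 4.8-fold lower number from compound 2 to compound 3 (0.68 log units; beyond the scatter). Chloro itself is untested, and the nearest guide is the small nitro step. In this assay the expected change is a 1.3-fold lower number from compound 3 to compound 4 (0.11 log units; within the scatter), with nothing expected beyond the scatter. Compound 4 is estimated at 16000 nM, within an expected range of 6000 nM to 42000 nM.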

Compound 4, concentration for 50% growth inhibition: 7350 nM
For compound 4 the middle estimate is 2.2-fold (0.34 log units) above the measured one; low and high end bracket the measured number.
By their numbers in this assay, from the lowest: compounds 4, 1 and 3 (each within the scatter of the next, the first and the last beyond it). At a limit, above all of these: compound 2.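

In this assay, for the compounds shown here, chloro gave a 2.8-fold lower number from compound 3 to compound 4 (0.45 log units; beyond the scatter) on this aromatic carbon para to a large group, the first step beyond the scatter here that does not involve dimethylamino. Chloro in place of hydrogen gave a 1.7-fold lower number from compound 1 to compound 4 (0.24 log units; within the scatter) and so, like nitro, stays level with hydrogen, although chloro and nitro part from each other. Chloro in place of dimethylamino gave an at least 13-fold lower number from compound 2 to compound 4 (1.13 log units; beyond the scatter) as a bound only: the limit of > 100000 nM in this assay, at which 1 of the 4 values shown sits.

As far as these compounds go, whether fluoro or bromo would follow chloro stays open, as does methoxy on the same carbon. From the compounds shown here alone, how chloro behaves on the other ring carbons also stays open.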